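A few compounds are considered here, and "the series" means these few. Any claim that something is new, unique, unknown or untested is made for them only; others in the source may bear on it.

Notes on the quinoxaline-dioxide amide series in an ADME assay on Vero cells (Chlorocebus sabaeus) for cytotoxicity, read by MTT assay, with a stated time of 72 h; on this read-out lower numbers stand for stronger inhibition and higher numbers for weaker inhibition.

Compound 1 `COc1ccc2c(c1)[n+]([O-])c(C(=O)NCc1ccccc1)c(C)[n+]2[O-]` carries a methoxy on the shared core; in this assay compound 1 gives "not determined" (no result reported), so no number is available for it. Compound 2 `Cc1c(C(=O)NCc2ccccc2)[n+]([O-])c2cc(F)ccc2[n+]1[O-]` is the fluoro analogue with a plain benzyl amide. In this assay compound 2 gives > 100 ug/mL, which is a limit of the assay and not a number; it stands at the limit of > 100 ug/mL in this assay, at which 1 of the 3 values shown sits. Compound 3 `Cc1c(C(=O)NCc2ccccc2)[n+]([O-])c2cc(F)c(F)cc2[n+]1[O-]` adds a second fluoro to the core, and in this assay compound 3 gives 18.4 ug/mL. Among the measured compounds shown here, the step of an at least 5.4-fold lower number from compound 2 to compound 3 (0.73 log units; beyond the scatter) is the only measured step in the set, and it concerns a change on the core, not on the benzyl side.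

Compound 4 `COc1ccc(CNC(=O)c2c(C)[n+]([O-])c3ccc(F)cc3[n+]2[O-])cc1` keeps the core of compound 2 unchanged and alters the benzyl group: methoxy in place of hydrogen on an aromatic carbon. For the measured compounds named here, no measured step touches the benzyl ring, so the step from compound 2 to compound 3 does not carry over to this change. In the absence of any bearing step, no movement beyond the scatter is expected; the step of a number no higher from compound 2 to compound 4 (the limit leaves the size open) is an estimate that rests on compound 2 alone. Compound 4 is therefore expected to give about 100 ug/mL in this assay, within a range from 35 ug/mL to 300 ug/mL, with a fair chance that only a limit is again reported.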

Compound 4, half-maximal inhibitory concentration: > 30 ug/mL
Compound 4: a limit, no number (the forecaster's own chance of this, stated with the estimate: 50%); the middle value lies beyond the limit too.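

In this assay compound 2 and compound 4 each give only a limit of the assay and not a number, so no step can be read between them. The compounds shown leave open whether methoxy in place of hydrogen on the benzyl ring shifts the value at all, and in which direction.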